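From hydroxy to dimethylamino on compound 1

This account rests on a few compounds, and the source may have more. Where it says the series, first, only, none or still open, it means among the compounds named here.

Measured so far in a physicochemical assay for lipophilicity, using the shake flask method, in phosphate buffer, measured as octanol-water partition, with a stated time of 30 min, at pH 7.4 (a lower number here means a more polar compound, a higher number a more lipophilic compound), are three compounds
- compound 1 `Cc1nc(CO)ccc1-c1cnc(NCc2c(F)ccc3c2CCO3)c2cn[nH]c(=O)c12` gives 2.4
- compound 2 `CN(C)Cc1ccc(C(=O)Nc2cnc(NCc3c(F)ccc4c3CCO4)n3cnnc23)cc1` gives 1.8
- compound 3 `CN(C)Cc1ccc2c(c1)CN(c1cnc(NCc3c(F)ccc4c3CCO4)n3cnnc13)C2=O` gives 1.6

Of these three, compound 1 stands highest. Its gaps to compound 2 and to compound 3 both lie beyond the usual scatter of repeated measurements. Those gaps are hard to read, though, since compound 1 differs from the other two in more than one place. Among the compounds with values here, the cleanest comparison in this kind of work is between two compounds that differ in one place only, and no such pair has been measured here.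

The next compound offers that kind of comparison. Compound 4 `Cc1nc(CN(C)C)ccc1-c1cnc(NCc2c(F)ccc3c2CCO3)c2cn[nH]c(=O)c12` keeps the core of compound 1 but has dimethylamino in place of hydroxy on a saturated chain carbon bound to an aromatic carbon and nothing else changes. Compound 2 at 1.8 and compound 3 at 1.6 also carry a dimethylamino group, but on another core, so they say little about this exchange on its own. The expected step of a number 0.10 log units higher from compound 1 to compound 4 (within the scatter) in this assay is small and upward, and it is not expected to go beyond the scatter. For compound 4 the estimated value is 2.5 with an expected range of 2 to 3 around it.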

Compound 4, distribution coefficient: 2
The estimate for compound 4 lay 0.50 log units above the measured number; low and high end bracket the measured number.
By their numbers in this assay, from the lowest: compounds 3, 2 and 4 (each within the scatter of the next, the first and the last beyond it); then compound 1.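

In this assay, within the data shown here, putting dimethylamino in place of hydroxy on a saturated chain carbon bound to an aromatic carbon gives a step of a number 0.40 log units lower from compound 1 to compound 4 (beyond the scatter), the first comparison here in which only one place changes. With the rest of the molecule held the same, this modest fall can be tied to the exchange itself and not to a difference in the core, which the earlier gaps could not offer. The entering group has more heavy atoms than hydroxy and no hydrogen-bond donor, but nothing available here explains why the number moves in this direction.

Among these compounds, the single exchange does not show how other groups would behave in this place: a methoxy group, a carboxylic acid or a longer chain ending in dimethylamino could each fall on either side of compound 4 in this assay. From the compounds shown here alone, it also remains open whether the same exchange from hydroxy to dimethylamino would give a step of similar size and direction on the different core of compound 2 and compound 3.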